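Trifluoromethyl for methyl on the pendant ring of compound 1

The source may hold more compounds than are shown below. What is called first, only, known or untested is meant among the compounds shown, and "the series" means these compounds.

Compound 1 `Cc1cccc(Cc2nc3cc(O[C@H]4CC[C@@H](C(=O)O)CC4)ccc3n2C)c1`: 42 nM
Compound 2 `Cc1cccc(Cc2c(C(N)=O)c3cc(O[C@H]4CC[C@@H](C(=O)O)CC4)ccc3n2C)c1`: 600 nM

Of the compounds shown here, two have been measured in an assay on isolated protein for inhibition of Long-chain-fatty-acid--CoA ligase 1 (Homo sapiens), read by mass spectrometry, with a stated time of 90 min, in the presence of a further agent that is not named here; a lower number here means a stronger inhibitor, a higher number a weaker inhibitor. Compound 1 gives 42 nM, the lowest of the two numbers. Its nearest neighbour is compound 2, which gives 600 nM, a higher number that lies beyond the usual scatter of repeated measurements.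

Compound 3 `Cn1c(Cc2cccc(C(F)(F)F)c2)nc2cc(O[C@H]3CC[C@@H](C(=O)O)CC3)ccc21` has not yet been measured. It differs from compound 1 in one place (trifluoromethyl in place of methyl on an aromatic carbon), on an aromatic carbon of a six-membered aromatic ring of carbon only, meta to a large group. Going by the values given here, no pair of measured compounds shows this change, so its size and direction can only be guessed.

Compound 3 is expected to stay close to compound 1 in this assay, with a step of a 1.2-fold higher number from compound 1 to compound 3 (0.08 log units; within the scatter) that is not expected to exceed the scatter. Compound 3 is therefore estimated at 50 nM, within a range from 15 nM to 170 nM.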

Compound 3, half-maximal inhibitory concentration: 190 nM
The estimate for compound 3 lay 3.8-fold (0.58 log units) below the measured number; the measured number lies above the stated range.
By their numbers in this assay, from the lowest: compound 1; then compound 3; then compound 2.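

The methyl on this aromatic carbon of compound 1 cannot be exchanged for trifluoromethyl without cost: in this assay the change gives a 4.5-fold higher number from compound 1 to compound 3 (0.66 log units; beyond the scatter). The pendant ring, unchanged until now among the measured compounds, is thus shown to affect the number, and 3-(trifluoromethyl)phenyl is a poorer fit to this assay's trend than 3-methylphenyl. Nothing measured here bears on the reason for this step.

The compounds shown leave open whether other replacements on this carbon, such as chlorine, a methoxy group or an ethyl group, would stay closer to compound 1, and whether a plain phenyl ring without any such group would give a lower or a higher number. They also leave open whether the same exchange would carry a similar step elsewhere on the ring or in compound 2.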